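Compound 3 to compound 4: methyl becomes methoxycarbonyl

The compounds below may be only part of what the source reports. "The series", "measured", "known", "first", "only" and "open" are said of these compounds alone.

Compound 3 `Cc1ccc(NC(=O)Nc2cc(C)nc3ccccc23)cc1` gives > 25000 nM in an ADME assay on HEK293 cells (Homo sapiens) for cytotoxicity, with a stated time of 72 h (on this read-out higher numbers stand for an effect only at larger amounts of compound and lower numbers for an effect already at smaller amounts), and this is a limit of the assay, not a number. Compound 2 `Cc1cc(NC(=O)Nc2ccccc2N)c2ccccc2n1` gives > 25000 nM, which is also a limit. Compound 1 `CCc1ccc(NC(=O)Nc2cc(C)nc3ccccc23)cc1` is the only one of the three with a true number, at 16000 nM.

Compound 4 `COC(=O)c1ccc(NC(=O)Nc2cc(C)nc3ccccc23)cc1` keeps the core of compound 3 and alters one group: methoxycarbonyl in place of methyl on an aromatic carbon. Methoxycarbonyl stands in place of methyl on an aromatic carbon, para to a large group.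

Going by the values given here, two measured steps bear on this change. The closer one is an at least 1.5-fold higher number from compound 1 to compound 3 (0.19 log units; that floor lies within the scatter), since it alters the group that leaves on the way to compound 4. The other is a step that the two limits leave unreadable from compound 2 to compound 3. Neither gives a firm size because of the limit of > 25000 nM in this assay, at which 2 of the 3 values shown sit. The larger group in compound 1 still gave only 16000 nM, so a step beyond the scatter is not expected in this assay. For compound 4, another limit is quite possible. Put as a number, the expected change is a number no higher from compound 3 to compound 4 (the limit leaves the size open). For compound 4 the estimate is 25000 nM, with an expected range from 12000 nM to 50000 nM.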

Compound 4, half-maximal effective concentration: 15000 nM
Compound 4: middle estimate off by 1.7-fold (0.22 log units), on the high side; the range from low to high includes it.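

At this aromatic carbon, para to a large group, this assay now has a second true number, where compound 1 alone had one before, and it comes with methoxycarbonyl, which brings oxygen atoms and 2 hydrogen-bond acceptors to the position. Replacing methyl gives an at least 1.6-fold lower number from compound 3 to compound 4 (0.22 log units; that floor lies within the scatter), and the full size of this change stays open because the starting value is a limit of the assay: the limit of > 25000 nM in this assay, at which 2 of the 4 values shown sit.

Set against ethyl, methoxycarbonyl gives a 1.1-fold lower number from compound 1 to compound 4 (0.03 log units; within the scatter), so in this assay these two groups cannot be told apart, despite their different atoms.

From the compounds shown here alone, whether a carboxylic acid, an amine or a longer chain at this aromatic carbon would give a number clearly beyond the scatter from those of compound 1 and compound 4 remains open. The compounds shown also leave open what methoxycarbonyl would do on another carbon of this six-membered aromatic ring.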